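The source may hold more compounds than are shown below. What is called first, only, known or untested is meant among the compounds shown, and "the series" means these compounds.

The compounds share one core, seen in compound 1 `O=C(COc1cccc2ccccc12)N/N=C/c1ccccc1Br` and compound 2 `O=C(COc1cccc2ccccc12)N/N=C/c1cccc([N+](=O)[O-])c1`. In an ADME assay on HEL cells (Homo sapiens) for cytotoxicity (a higher number here means that more compound is tolerated, a lower number that less compound is tolerated), compound 1 reaches only a limit of >= 20 ug/mL. Compound 2 likewise reaches only a limit of >= 20 ug/mL. Compound 3 `O=C(COc1cccc2ccccc12)N/N=C/c1ccc(F)cc1` stands alone with a real number, giving 100 ug/mL in this assay. The step that the limit leaves unreadable from compound 1 to compound 3 cannot be sized because the limit of >= 20 ug/mL in this assay, at which 2 of the 3 values shown sit, hides where compound 1 truly lies. Compound 4 `O=C(COc1cccc2ccccc12)N/N=C/c1cccc(Cl)c1` differs from compound 3 by 3-chlorophenyl in place of 4-fluorophenyl on a carbon with a double bond to nitrogen. Among the measured compounds shown here, no measured step bears on this change, so no shift beyond the scatter is expected in this assay. Compound 4 is therefore estimated at 70 ug/mL, within a range from 20 ug/mL to 200 ug/mL. The expected step of a 1.4-fold lower number from compound 3 to compound 4 (0.15 log units; within the scatter) is small.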

Compound 4, minimum cytotoxic concentration: 100 ug/mL
Estimate against measurement, compound 4: 1.4-fold (0.15 log units) below; low and high end bracket the measured number.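

In this assay, putting 3-chlorophenyl in place of 4-fluorophenyl on a carbon with a double bond to nitrogen gives no change at the digits printed from compound 3 to compound 4 (within the scatter). Among the compounds shown here, this is the first readable step at this position, where the earlier compounds offered none. The steps from compound 1 and from compound 2 to compound 4 cannot be read, because they start from a value that is only a limit: the limit of >= 20 ug/mL in this assay, at which 2 of the 4 values shown sit.

The compounds shown leave open whether compound 1 and compound 2 would match compound 4 if given real numbers. They also leave open how an amine or a carboxylic acid in place of the chloro group would read in this assay.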